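From Hydroxy to Methylsulfonyl in a Cell Assay

The source may report more compounds than this note shows. Statements on the series, on what has been measured and on what is new or still open speak of the compounds shown alone.

In a functional assay on HCT-116 cells (Homo sapiens) for cytotoxicity, with a stated time of 48 h (on this read-out higher numbers stand for weaker inhibition and lower numbers for stronger inhibition), compound 3 (`Oc1ccc(-c2cncc(-c3cc4cc(O)ccc4[nH]3)n2)cc1`) gives 6000 nM. That lies within the scatter of compound 2 (`N#Cc1ccc(-c2cncc(-c3cc4cc(O)ccc4[nH]3)c2)cc1`), at 9000 nM, while compound 1 (`CS(=O)(=O)c1ccc(-c2cncc(-c3cc4ccc(O)cc4[nH]3)c2)cc1`), at 2000 nM, shows a lower number beyond the scatter, meaning stronger inhibition. Compound 4 (`CS(=O)(=O)c1ccc(-c2cncc(-c3cc4cc(O)ccc4[nH]3)n2)cc1`) has methylsulfonyl in place of hydroxy on an aromatic carbon. Among the measured compounds shown here, no measured pair isolates this change. Compound 1 also carries methylsulfonyl, on a differing core, and gives 2000 nM, so a small shift toward stronger inhibition, probably within the scatter, seems likely. The expected step is a 1.5-fold lower number from compound 3 to compound 4 (0.18 log units; within the scatter). For compound 4 the estimated value is 4000 nM, with an expected range of 1500 nM to 10000 nM.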

Compound 4, half-maximal inhibitory concentration: 2500 nM
For compound 4 the middle estimate is 1.6-fold (0.20 log units) above the measured one; the range from low to high includes it.
By their numbers in this assay, from the lowest: compounds 1 and 4 (each within the scatter of the next); then compounds 3 and 2 (each within the scatter of the next).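

Among the compounds shown here, replacing hydroxy with methylsulfonyl on this aromatic carbon, para to a large group, is the first change here that can be read on its own: in this assay it brings a 2.4-fold lower number from compound 3 to compound 4 (0.38 log units; beyond the scatter) and so a modest gain in inhibition. The hydroxy at this position is therefore not needed for this level of inhibition, and the larger group, which has no hydrogen-bond donor, is accepted. Nothing available explains why the number falls. Going by these compounds, whether an amine or a carboxylic acid at this position would give stronger or weaker inhibition remains open. So does whether the same change would give a similar step on a different core.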